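A few compounds are considered here, and "the series" means these few. Any claim that something is new, unique, unknown or untested is made for them only; others in the source may bear on it.

In a functional assay on HCT-116 cells (Homo sapiens) for antiproliferative activity, read by MTT assay, with a stated time of 48 h (a lower number here means a stronger inhibitor, a higher number a weaker inhibitor), compound 1 (`CCOc1cc(-c2ccc3cc[nH]c3c2)cn2c(-c3cc(OC)c(OC)c(OC)c3)nnc12`) gives 1340 nM. Compound 2 (`COc1cc(-c2nnc3c(OC4COC4)cc(-c4ccc5[nH]ccc5c4)cn23)cc(OC)c1OC`) gives 5370 nM, the higher of the two numbers and so the weaker result, by a gap beyond the usual scatter. Compound 3 (`COc1cc(-c2nnc3c(OC4CN(C(C)(C)C)C4)cc(-c4ccc5[nH]ccc5c4)cn23)cc(OC)c1OC`) departs from compound 2 in one place, (1-(tert-butyl)azetidin-3-yl in place of oxetan-3-yl on an oxygen on an aromatic ring), with 1-(tert-butyl)azetidin-3-yl in place of oxetan-3-yl on an oxygen on an aromatic ring. For the measured compounds named here, no measured pair shows this change, so any expectation is loose. The expected step of a 1.3-fold lower number from compound 2 to compound 3 (0.13 log units; within the scatter) is small, leaning slightly toward a lower number and not beyond the scatter. In this assay, compound 3 is estimated at 4000 nM, within a range of 1200 nM to 14000 nM.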

Compound 3, half-maximal inhibitory concentration: > 10000 nM
Compound 3: no number, only a limit (the forecaster's own chance of this, stated with the estimate: 10%); middle value at least 2.5-fold (0.39 log units) away from the limit.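

In this assay, compound 3 gives no exact number, only a limit of the assay: the limit of > 10000 nM in this assay, at which 1 of the 3 values shown sits. The step is an at least 1.8-fold higher number from compound 2 to compound 3 (0.27 log units; that floor lies within the scatter), so placing 1-(tert-butyl)azetidin-3-yl on this oxygen brings no gain over oxetan-3-yl, although that floor alone does not establish a real loss. This is the first nitrogen-containing ring shown at this position, and it does not give a lower number.

From the compounds shown here alone, it remains open whether the tert-butyl group or the azetidine ring governs this result. An azetidine carrying methyl on its nitrogen, or an open-chain amine such as 2-(dimethylamino)ethyl, could separate the two.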